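A Phenyl-to-Pyridinyl Swap Tested at a Second Position

This account rests on a few compounds, and the source may have more. Where it says the series, first, only, none or still open, it means among the compounds named here.

Measured compounds:
compound 1 `O=C(O)c1ccc2noc(-c3ccc(Oc4ccccc4)cc3)c2c1`: 280 nM
compound 2 `O=C(O)c1ccc2noc(-c3ccc(Oc4ccccn4)cc3)c2c1`: 1190 nM
compound 3 `O=C(O)c1ccc2noc(-c3cccc(Oc4ccccc4)c3)c2c1`: 130 nM

All three were run in an assay for inhibition of inositol hexakisphosphate kinase 2 (Homo sapiens), read by colorimetric assay, coupled enzyme assay and malachite green, with a stated time of 120 min, in the presence of a further agent that is not named here; a lower number here means a stronger inhibitor, a higher number a weaker inhibitor. Compound 1 and compound 3 are built from the same atoms joined differently; the difference between the two cores is not broken down here. Among the three, compound 3 gives the lowest number, with compound 1 nearest and compound 2 furthest away.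

Between compound 1 and compound 2 the change is pyridin-2-yl in place of phenyl on an oxygen on an aromatic ring. This step, a 4.3-fold higher number from compound 1 to compound 2 (0.63 log units; beyond the scatter), moved the number upward by a modest but clear amount.

The unmeasured compound 4 `O=C(O)c1ccc2noc(-c3cccc(Oc4ccccn4)c3)c2c1` carries the same change applied to compound 3: pyridin-2-yl in place of phenyl on an oxygen on an aromatic ring. The place line reads identically in both cases, so it is the same change made on a different core. Within the data shown here, only one instance of this change has been measured, so the expectation rests on a single precedent.

Because compound 1 to compound 2 gave a 4.3-fold higher number from compound 1 to compound 2 (0.63 log units; beyond the scatter), a step of similar size is expected from compound 3 to compound 4, namely a 4.3-fold higher number from compound 3 to compound 4 (0.63 log units; beyond the scatter). Compound 4 is therefore estimated to give 560 nM in this assay, with a likely range from 250 nM to 1300 nM.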

Compound 4, half-maximal inhibitory concentration: 690 nM
Estimate against measurement, compound 4: 1.2-fold (0.09 log units) below; the measured number falls inside the stated range.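

In this assay, pyridin-2-yl in place of phenyl on an oxygen on an aromatic ring again gave a weaker inhibitor, with a 5.3-fold higher number from compound 3 to compound 4 (0.72 log units; beyond the scatter). Set beside the earlier step, the change carried from one core to the other with no difference in size that can be told apart: the same change on two cores in this assay, a 4.3-fold higher number (0.63 log units; beyond the scatter) from compound 1 to compound 2 and a 5.3-fold higher number (0.72 log units; beyond the scatter) from compound 3 to compound 4, 1.2-fold (0.10 log units) apart, within the scatter of two such steps. Among these compounds, this shows that the step kept its direction and its approximate size on these two cores, but it rests on only two pairs in a single assay, so it does not show that the change would behave the same way on any other core, and it says nothing about why the number rises.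

The compounds shown leave open how groups other than phenyl and pyridin-2-yl would behave on that oxygen, for example a cyclohexyl or a methyl group, and whether a chloro or a methoxy substituent on the phenyl ring would shift the number in the same way on both cores. They also leave open whether the carboxylic acid shared by all four compounds could give way to an amide or a nitrile while the number stays in the same range.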